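This account rests on a few compounds, and the source may have more. Where it says the series, first, only, none or still open, it means among the compounds named here.

Measured compounds:
compound 1, `Cc1ccc(NN=C2CCC(C)n3c2ncc(C(=O)O)c3=O)cc1C`, > 100 umol/kg
compound 2, `Cc1cccc(C)c1NN=C1CCC(C)n2c1ncc(C(=O)O)c2=O`, 320 umol/kg
compound 3, `Cc1cc(C)c(NN=C2CCC(C)n3c2ncc(C(=O)O)c3=O)c(C)c1`, 320 umol/kg

All three were tested in a functional assay on the whole organism with Rattus norvegicus as the target; on this read-out higher numbers stand for an effect only at larger amounts of compound and lower numbers for an effect already at smaller amounts. For compound 1 the value > 100 umol/kg is a limit of the assay, not a number. Compound 2 gives 320 umol/kg in this assay, and compound 3 gives 320 umol/kg. Compound 1 and compound 2 share all their atoms but join them differently: 3,4-dimethylphenyl in place of 2,6-dimethylphenyl on an amine nitrogen. The step that the limit leaves unreadable from compound 1 to compound 2 cannot be read because of the limit of > 100 umol/kg in this assay, at which 1 of the 3 values shown sits. The step of no change at the digits printed from compound 2 to compound 3 (within the scatter) comes from one change, (methyl in place of hydrogen on an aromatic carbon).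

Compound 4, `Cc1cc(C)c(NN=C2CCC(C)n3c2ncc(C(=O)O)c3=O)cc1C`, is not yet measured in this assay. It differs from compound 1 by methyl in place of hydrogen on an aromatic carbon. Going by the values given here, this is the same kind of change as the one from compound 2 to compound 3, though the place differs: in compound 3 the methyl enters meta to two methyl groups and para to a large group, while in compound 4 it enters ortho to a large group, meta to a methyl group and para to a methyl group. Since the step from compound 2 to compound 3 stayed within the scatter, the step from compound 1 to compound 4 is expected to be small as well, a step that the limit leaves unreadable from compound 1 to compound 4, resting on no change at the digits printed from compound 2 to compound 3 (within the scatter) and on compound 1 sitting at the limit > 100 umol/kg. Compound 4 is therefore estimated at about 250 umol/kg, likely between 80 umol/kg and 1000 umol/kg, with a fair chance that the assay again reports only a limit.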

Compound 4, dose for 50% inhibition: 320 umol/kg
Beside the measured number, compound 4's estimate is 1.3-fold (0.11 log units) below it, and the stated range covers the measured number.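

The size of the step from compound 1 to compound 4 cannot be read, because compound 1 has only a limit and no exact number to compare: the limit of > 100 umol/kg in this assay, at which 1 of the 4 values shown sits. The compounds shown leave open how much the added methyl changes the dose needed in compound 1, and whether 3,4-dimethylphenyl in compound 1 and 2,6-dimethylphenyl in compound 2 truly differ.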